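The source may report more compounds than this note shows. Statements on the series, on what has been measured and on what is new or still open speak of the compounds shown alone.

Compound 1, `Cc1cc(NC(=O)Cn2nnc(-c3cc(Cl)cc(Cl)c3)n2)n(C2CCCCC2)n1`, was tested in an assay on HEK293 cells for activation of Kir3.1/Kir3.2 (Homo sapiens), read by thallium flux (a higher number here means a larger maximal response, a lower number a smaller maximal response), and gave 82%. Compound 2, `Cc1cc(NC(=O)Cn2nnc(C3CC3)n2)n(C2CCCCC2)n1`, carries cyclopropyl in place of 3,5-dichlorophenyl on an aromatic carbon. In this assay compound 2 is reported only as a limit, > 68%, so its standing is a bound rather than a number. Among the compounds with values here, the step that the limit leaves unreadable from compound 1 to compound 2 therefore cannot be sized; the only evidence is the limit of > 68% in this assay, at which 1 of the 2 values shown sits. Compound 3, `Cc1cc(NC(=O)Cn2nnc(-c3ccc(Cl)c(C)c3)n2)n(C2CCCCC2)n1`, differs from compound 2 in that (4-chloro-3-methylphenyl in place of cyclopropyl on an aromatic carbon). Within the data shown here, no measured step bears on this change directly, because the one step recorded, a step that the limit leaves unreadable from compound 1 to compound 2, is unreadable. Since compound 3 again bears an aryl group at the same place as compound 1, whose response was 82%, compound 3 is expected to give roughly 80%, within 65% to 95%, implying an estimated step that the limit leaves unreadable from compound 2 to compound 3 of no clear size beyond the scatter.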

Compound 3, largest response reached (Emax), in percent of the reference or control that the assay uses: 89%
For compound 3 the middle estimate is 9 percentage points below the measured one; measured number inside the range.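

In this assay, 4-chloro-3-methylphenyl in place of 3,5-dichlorophenyl on the aromatic carbon gives a number 7 percentage points higher from compound 1 to compound 3 (within the scatter). Two differently substituted phenyl groups at this place therefore give responses within the scatter of each other, which compound 1 alone could not show. Compound 2 is reported only as a limit, so the steps that involve it cannot be read, and cyclopropyl cannot be sized against either aryl group: the limit of > 68% in this assay, at which 1 of the 3 values shown sits.

From the compounds shown here alone, whether cyclopropyl truly differs from these aryl groups stays open. Also open, going by these compounds, is what a phenyl group without substituents, or one carrying a carboxylic acid or an amine, would give on this aromatic carbon.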